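A few compounds are considered here, and "the series" means these few. Any claim that something is new, unique, unknown or untested is made for them only; others in the source may bear on it.

Measured so far:
- compound 1 `Nc1nc(Cl)c2ncn(Cc3ccccc3CCl)c2n1`: 70800 nM
- compound 2 `ClCc1ccccc1Cn1cnc2nc(Cl)nc(Cl)c21`: 7240 nM
- compound 3 `ClCc1ccc(Cn2cnc3c(Cl)nc(Cl)nc32)cc1`: 42700 nM

In a functional assay on DU-145 cells (Homo sapiens) for cytotoxicity, read by sulforhodamine B assay, with a stated time of 48 h (on this read-out higher numbers stand for lower toxicity in this test and lower numbers for higher toxicity in this test), compound 1 gives the highest number of the three. Compound 3 sits within the scatter of it, while compound 2 lies well beyond, at a clearly lower number. Among the compounds with values here, no step between two measured compounds that differ in one place is available.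

Compound 4 `ClCc1ccccc1Cn1cnc2c(Cl)nc(Cl)nc21` is not yet measured. From compound 1 it differs in one place: chloro in place of amino on an aromatic carbon. Within the data shown here, with no measured step of this kind, the expectation rests on the two dichloro compounds, compound 2 and compound 3, both of which show lower numbers than compound 1. The step from compound 1 to compound 4 is expected to be modest, toward a lower number, roughly a 2.4-fold lower number from compound 1 to compound 4 (0.37 log units; beyond the scatter). Compound 4 is estimated at 30000 nM (range 8000 nM to 80000 nM).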

Compound 4, concentration lethal to 50% of the cells: 6310 nM
Estimate against measurement, compound 4: 4.8-fold (0.68 log units) above; measured number below the stated range.
By their numbers in this assay, from the lowest: compounds 4 and 2 (each within the scatter of the next); then compounds 3 and 1 (each within the scatter of the next).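

In this assay, within the data shown here, chloro in place of amino on an aromatic carbon, between two ring nitrogen atoms, gives an 11-fold lower number from compound 1 to compound 4 (1.05 log units; beyond the scatter) as the first measured one-place step. The size of this step shows that the read-out is sensitive to the group at this position, with chloro giving the higher toxicity in this test. Nothing available accounts for the size of the step.

Open, as far as these compounds go, is how a methoxy group, a methylamine or a plain hydrogen at this position would compare with amino and chloro. Also open, from the compounds shown here alone, is whether the step holds on other compounds.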